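From compound 2 to compound 3: replacing the bromine

The source may report more compounds than this note shows. Statements on the series, on what has been measured and on what is new or still open speak of the compounds shown alone.

Measured in a functional assay on HCT-116 cells (Homo sapiens) for antiproliferative activity, read by MTT assay, with a stated time of 48 h; a lower number here means a stronger inhibitor, a higher number a weaker inhibitor:
- compound 1 `COc1ccc(N(C)c2ccnc(Cl)n2)cc1Cl`: 1170 nM
- compound 2 `COc1ccc(N(C)c2ccnc(Cl)n2)cc1OCCCCBr`: 1140 nM

In this assay, compound 2 stands level with compound 1, as a 1.0-fold lower number from compound 1 to compound 2 (0.01 log units; within the scatter) shows. Compound 3 `COc1ccc(N(C)c2ccnc(Cl)n2)cc1OCCCC[Se]C#N` is compound 2 with one change: a group of 3 heavy atoms (1 carbon, 1 nitrogen, 1 selenium; no ring) in place of one bromine atom, on a saturated chain carbon, four bonds along the chain from an oxygen on an aromatic ring. Within the data shown here, the only measured step was made at a different place, on an aromatic carbon, so it offers weak guidance and no measured step tests this new group. Expected, tentatively, is a 1.6-fold lower number from compound 2 to compound 3 (0.21 log units; within the scatter), a modest move to a lower number with no firm direction from the data. The estimate for compound 3 is 700 nM, within a wide range of 150 nM to 1800 nM.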

Compound 3, half-maximal inhibitory concentration: > 10000 nM
Compound 3 was reported as a limit; the forecaster's own chance of this, stated with the estimate: 3%; at least 14-fold (1.15 log units) between middle value and limit.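

In this assay, the end of this chain turns out to matter: putting the selenium-bearing group in place of the bromine gives an at least 8.7-fold higher number from compound 2 to compound 3 (0.94 log units; beyond the scatter), whereas the earlier change on an aromatic carbon stayed within the scatter. Against the chloro compound, the whole chain with this group gives an at least 8.5-fold higher number from compound 1 to compound 3 (0.93 log units; beyond the scatter). Compound 3 is reported only as a limit: the limit of > 10000 nM in this assay, at which 1 of the 3 values shown sits.

On these data alone, whether an amine or a carboxylic acid at the same chain end would keep the activity of compound 2 stays open. So does the effect of a shorter or longer chain.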